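Swapping an amine side chain on a sulfamate amide series

The compounds below may be only part of what the source reports. "The series", "measured", "known", "first", "only" and "open" are said of these compounds alone.

Measured compounds:
- compound 1 `CCN(Cc1cccc(Br)c1)c1ccc(C(=O)N2CCc3ccc(OS(N)(=O)=O)cc3C2)cc1`: 80.2%
- compound 2 `CC(C)CCN(CCC(C)C)c1ccc(C(=O)N2CCc3ccc(OS(N)(=O)=O)cc3C2)cc1`: 47%
- compound 3 `CN(CCN1CCCCC1)c1ccc(C(=O)N2CCc3ccc(OS(N)(=O)=O)cc3C2)cc1`: 0.3%

All three share one core and differ only in the amino group attached to an aromatic carbon. In an assay on HEK293 cells for inhibition of Steryl-sulfatase (Homo sapiens), tested at 0.1 uM (on this read-out higher numbers stand for a stronger effect at the one concentration tested and lower numbers for a weaker effect), compound 3 stands lowest of the three; its nearest neighbour is compound 2, and compound 1 lies furthest away, both separated from it by more than the scatter. The unmeasured compound 4 `CCN(Cc1ccncc1)c1ccc(C(=O)N2CCc3ccc(OS(N)(=O)=O)cc3C2)cc1` carries the change (ethyl((pyridin-4-yl)methyl)amino in place of methyl(2-(piperidin-1-yl)ethyl)amino on an aromatic carbon).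

Among the compounds with values here, two measured steps bear on this. The step of a number 79.9 percentage points lower from compound 1 to compound 3 (beyond the scatter) shows how much is lost when a benzyl-type group is exchanged for the piperidinyl-ethyl chain, and the step of a number 46.7 percentage points lower from compound 2 to compound 3 (beyond the scatter) points the same way from a branched alkyl pair. Compound 4 returns to an ethyl and an arylmethyl group on the nitrogen, closely resembling compound 1, so a large rise in this assay is expected, with a number 54.7 percentage points higher from compound 3 to compound 4 (beyond the scatter) as the estimated step. Compound 4 is therefore estimated at 55%, within a range of 25% to 85%.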

Compound 4, a percentage reported as inhibition, at one concentration (the size of the read-out at that concentration, not a potency): 47%
Compound 4: the middle estimate sits 8 percentage points above what was measured; low and high end bracket the measured number.
By their numbers in this assay, from the lowest: compound 3; then compounds 2 and 4 (each within the scatter of the next); then compound 1.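

Exchanging methyl(2-(piperidin-1-yl)ethyl)amino for ethyl((pyridin-4-yl)methyl)amino changes the read-out in this assay substantially (a number 46.7 percentage points higher from compound 3 to compound 4 (beyond the scatter)), although the two groups have the same counts of heavy atoms, hydrogen-bond donors and acceptors, so these counts alone do not set the result at this position. Keeping the ethyl group and the methylene link while replacing 3-bromophenyl with pyridin-4-yl also matters (a number 33.2 percentage points lower from compound 1 to compound 4 (beyond the scatter)), so the ring at the end of the side chain counts, not only the general ethyl-and-arylmethyl shape. Meanwhile, diisopentylamino and ethyl((pyridin-4-yl)methyl)amino cannot be told apart (no change at the digits printed from compound 2 to compound 4 (within the scatter)), even though one has no ring and the other has an aromatic one.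

Nothing shown here explains these differences. On these data alone, a plain benzyl group on the same nitrogen would help show whether the step from compound 1 to compound 4 follows the loss of the bromine or the presence of the ring nitrogen, and that question remains open.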